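A few compounds are considered here, and "the series" means these few. Any claim that something is new, unique, unknown or untested is made for them only; others in the source may bear on it.

Measured so far:
- compound 1 `Cc1cccc(NC(=O)/C(C#N)=C/c2cc(O)c(O)c([N+](=O)[O-])c2)c1`: 12.5 ug/mL
- compound 2 `N#C/C(=C\c1cc(O)c(O)c([N+](=O)[O-])c1)C(=O)Nc1ccccc1Cl`: 37.4 ug/mL

In a functional assay on KB cells (Homo sapiens) for antiproliferative activity, read by MTT assay (on this read-out lower numbers stand for stronger inhibition and higher numbers for weaker inhibition), compound 2 has the highest of the two numbers; its nearest neighbour is compound 1, and the step from compound 1 to compound 2 was a 3.0-fold higher number from compound 1 to compound 2 (0.48 log units; beyond the scatter), a modest change. Compound 3 `N#C/C(=C\c1cc(O)c(O)c([N+](=O)[O-])c1)C(=O)N1CCCCC1` is compound 2 with piperidin-1-yl in place of (2-chlorophenyl)amino on a carbonyl carbon. Among the compounds with values here, only that one measured step bears on this, and it swapped one aryl group for another while keeping the amide hydrogen; compound 3 loses that hydrogen and the aromatic ring altogether, so the guidance is weak, and a further weakening is thought more likely than not. Compound 3 is expected to give about 55 ug/mL, within a range from 15 ug/mL to 200 ug/mL. That would amount to an estimated step of a 1.5-fold higher number from compound 2 to compound 3 (0.17 log units; within the scatter).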

Compound 3, half-maximal inhibitory concentration: > 100 ug/mL
Compound 3: no number, only a limit; the forecaster's own chance of this, stated with the estimate: 10%; at least 1.8-fold (0.25 log units) between middle value and limit.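

In this assay compound 3 gives > 100 ug/mL, which is a limit of the assay and not a number. Within the data shown here, earlier, only one aryl group was swapped for another, whereas piperidin-1-yl on the carbonyl carbon gives an at least 2.6-fold higher number from compound 2 to compound 3 (0.42 log units; beyond the scatter) and an at least 8.0-fold higher number from compound 1 to compound 3 (0.90 log units; beyond the scatter), so a non-aromatic ring without the amide hydrogen clearly weakens inhibition here.

The aromatic ring and the amide hydrogen leave together, so the compounds shown cannot tell which loss matters. A cyclohexylamino group, with a non-aromatic ring and the amide hydrogen kept, would separate the two.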